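Quinolin-8-yl in place of 1H-indol-5-yl: a higher number expected

The compounds below may be only part of what the source reports. "The series", "measured", "known", "first", "only" and "open" are said of these compounds alone.

In a functional assay on DU-145 cells (Homo sapiens) for inhibition, read by trypan blue exclusion, with a stated time of 72 h (a higher number here means a weaker inhibitor, a lower number a stronger inhibitor), compound 1 `COc1ccc(Nc2ncc3cc(S(=O)(=O)c4ccc(C)cc4)c(=O)n(C)c3n2)cc1` gives 100000 nM, compound 2 `Cc1ccc(S(=O)(=O)c2cc3cnc(Nc4cnc5[nH]ccc5c4)nc3n(C)c2=O)cc1` gives 25000 nM and compound 3 `Cc1ccc(S(=O)(=O)c2cc3cnc(Nc4ccc5[nH]ccc5c4)nc3n(C)c2=O)cc1` gives 750 nM, the lowest of the three numbers. Compound 4 `Cc1ccc(S(=O)(=O)c2cc3cnc(Nc4cccc5cccnc45)nc3n(C)c2=O)cc1` differs from compound 3 by quinolin-8-yl in place of 1H-indol-5-yl on a nitrogen on an aromatic ring. Two measured steps change the group at this place, a 130-fold lower number from compound 1 to compound 3 (2.12 log units; beyond the scatter) and a 33-fold lower number from compound 2 to compound 3 (1.52 log units; beyond the scatter), and both are large and favour the 1H-indol-5-yl group of compound 3. Going by the values given here, no measured compound carries quinolin-8-yl, so the size remains uncertain. A large rise in the number is expected, a 13-fold higher number from compound 3 to compound 4 (1.12 log units; beyond the scatter). For compound 4 the estimated value is 10000 nM, with an expected range of 2000 nM to 60000 nM.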

Compound 4, half-maximal inhibitory concentration: 10000 nM
Beside the measured number, compound 4's estimate shows no gap at the digits printed, and the stated range covers the measured number.
By their numbers in this assay, from the lowest: compound 3; then compound 4; then compound 2; then compound 1.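

In this assay, quinolin-8-yl on the nitrogen gives a 13-fold higher number from compound 3 to compound 4 (1.12 log units; beyond the scatter), so two aromatic rings at this place do not by themselves match 1H-indol-5-yl. The same group still gives a 2.5-fold lower number from compound 2 to compound 4 (0.40 log units; beyond the scatter) and a 10-fold lower number from compound 1 to compound 4 (1.00 log units; beyond the scatter), placing it second among the four groups at this position. The change swaps a hydrogen-bond donor for an acceptor and a five-membered ring for a six-membered one, and nothing available separates these differences. Which of them carries the step remains open. Also open, on these data alone, is how an amine or a carboxylic acid on 1H-indol-5-yl would read in this assay.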